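Shifting the fluorine on the amide-bound phenyl

A few compounds are considered here, and "the series" means these few. Any claim that something is new, unique, unknown or untested is made for them only; others in the source may bear on it.

Compound 1 `CNC(=O)c1cc(C)n(Cc2cc(Cl)ccc2OCc2ccccc2)n1` carries a methyl on its amide nitrogen. In a physicochemical assay for lipophilicity, at pH 7.4 (on this read-out higher numbers stand for higher lipophilicity and lower numbers for lower lipophilicity), compound 1 reaches only a limit of the assay, > 3.7. Compound 2 `Cc1cc(C(=O)Nc2ccccc2)nn1Cc1cc(Cl)ccc1OCc1ccccc1` bears a phenyl on that nitrogen instead; in this assay compound 2 likewise gives a limit, > 3.7. Compound 3 `Cc1cc(C(=O)Nc2cccc(F)c2)nn1Cc1cc(Cl)ccc1OCc1ccccc1` carries a 3-fluorophenyl there, and in this assay compound 3 gives 2.8. Among the compounds with values here, compound 3 thus holds the only number among the three, the other two resting at a limit (the limit of > 3.7 in this assay, at which 2 of the 3 values shown sit). The step that the two limits leave unreadable from compound 1 to compound 2 cannot be read, whereas a number at least 0.90 log units lower from compound 1 to compound 3 (beyond the scatter) and a number at least 0.90 log units lower from compound 2 to compound 3 (beyond the scatter) both lie beyond the scatter.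

Compound 4 `Cc1cc(C(=O)Nc2ccc(F)cc2)nn1Cc1cc(Cl)ccc1OCc1ccccc1` differs from compound 3 by 4-fluorophenyl in place of 3-fluorophenyl on an amide-type nitrogen. Within the data shown here, no measured step exchanges one fluorophenyl for another; the only step that touches the fluorine, a number at least 0.90 log units lower from compound 2 to compound 3 (beyond the scatter), concerns its presence rather than where on the ring it stands. The change is therefore expected to give a step no larger than the scatter, a number 0.10 log units higher from compound 3 to compound 4 (within the scatter). Compound 4 is estimated at 2.9, in the range 2.4 to 3.5.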

Compound 4, distribution coefficient: 3
Estimate against measurement, compound 4: 0.10 log units below; measured number inside the range.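

In this assay, 4-fluorophenyl in place of 3-fluorophenyl on the amide-type nitrogen gives a number 0.20 log units higher from compound 3 to compound 4 (within the scatter), so moving the fluorine between these two ring places leaves no readable difference. The lower reading seen with the first fluorophenyl recurs with the second: fluoro in place of hydrogen gives a number at least 0.70 log units lower from compound 2 to compound 4 (beyond the scatter), and 4-fluorophenyl in place of methyl gives a number at least 0.70 log units lower from compound 1 to compound 4 (beyond the scatter). These two steps are bounds only, and their full size remains unknown, since each starts from a compound that reaches a limit and not a number: the limit of > 3.7 in this assay, at which 2 of the 4 values shown sit.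

The step between the methyl and phenyl amides, compound 1 and compound 2, cannot be read either. On these data alone, what an amine, a carboxylic acid or a nitrile on this phenyl would do in this assay stays open, as does whether a longer chain on the amide nitrogen would read differently from the methyl of compound 1.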